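The source may hold more compounds than are shown below. What is called first, only, known or untested is meant among the compounds shown, and "the series" means these compounds.

Measured compounds:
compound 1, `O=C(Nc1ccc(F)cc1)N1N=C(c2ccc(Br)cc2)CC1c1ccc(F)cc1`: 16 nM
compound 2, `O=C(Nc1ccncc1)N1N=C(c2ccccc2)CC1c1ccc(F)cc1`: 202 nM

Both values come from an assay on HEK293 cells for inhibition of Voltage-dependent T-type calcium channel subunit alpha-1H (Homo sapiens), read by FLIPR and calcium flux, with a stated time of 3 min; a lower number here means a stronger inhibitor, a higher number a weaker inhibitor. Compound 2 stands at the higher of the two numbers; compound 1 gives 16 nM, a lower number by a margin beyond the scatter. Within the data shown here, no single-change step connects the two measured compounds.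

Compound 3, `O=C(Nc1ccc(F)cc1)N1N=C(c2ccccc2)CC1c1ccc(F)cc1`, is not yet measured. It differs from compound 2 in one place: 4-fluorophenyl in place of pyridin-4-yl on an amide-type nitrogen. Among the measured compounds shown here, compound 1 shows that a 4-fluorophenyl on the amide-type nitrogen goes together with the lower of the two numbers seen, though compound 1 also differs from compound 3 elsewhere, so that pair yields no clean step. The expectation is a move from compound 2 toward the lower number, estimated as a 5.1-fold lower number from compound 2 to compound 3 (0.70 log units; beyond the scatter), a step beyond the scatter. Compound 3 is expected at 40 nM, with a range of 15 nM to 120 nM.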

Compound 3, half-maximal inhibitory concentration: 25 nM
Compound 3: middle estimate off by 1.6-fold (0.20 log units), on the high side; low and high end bracket the measured number.
By their numbers in this assay, from the lowest: compounds 1 and 3 (each within the scatter of the next); then compound 2.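

In this assay, among these compounds, the pair of compound 2 and compound 3 gives the first clean reading at the amide-type nitrogen, with an 8.1-fold lower number from compound 2 to compound 3 (0.91 log units; beyond the scatter) for 4-fluorophenyl in place of pyridin-4-yl while the rest of the structure stays fixed. Bromo and hydrogen on the aromatic carbon are not separated by a 1.6-fold higher number from compound 1 to compound 3 (0.19 log units; within the scatter) and so, among these compounds, only the change on the amide-type nitrogen gives a step beyond the scatter. Nothing available explains the size of that step.

What the compounds shown leave open is how a plain phenyl, a cyclohexyl or a short chain ending in an amine would read on the amide-type nitrogen. Also open, going by these compounds, is whether a methoxy or a carboxylic acid on the aromatic carbon that carries bromo in compound 1 would stay within the scatter of hydrogen.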